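Urea-to-amide swap at the carbonyl of compound 2

The source may hold more compounds than are shown below. What is called first, only, known or untested is meant among the compounds shown, and "the series" means these compounds.

Measured so far:
compound 1 `O=C(Nc1cccc(-n2cc(-c3ccncc3)c(-c3cc(O)cc(Cl)c3)n2)c1)Nc1ccc(Cl)c(Cl)c1` gives 5%
compound 2 `COc1cc(Cl)cc(-c2nn(-c3cccc(NC(=O)Nc4ccc(Cl)c(Cl)c4)c3)cc2-c2ccncc2)c1` gives 3%

The series is read in a functional assay on K562 cells (Homo sapiens) for inhibition, read by sulforhodamine B assay, with a stated time of 48 h, tested at 100 uM; on this read-out lower numbers stand for a stronger effect and higher numbers for a weaker effect at the one concentration tested. Compound 1 and compound 2 differ only by methyl in place of hydrogen on an oxygen on an aromatic ring, and that step, a number 2 percentage points lower from compound 1 to compound 2 (within the scatter), did not separate them. Compound 2 therefore stands with compound 1 as a pair of indistinguishable low read-outs, with no other measured neighbour.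

Compound 3 `COc1cc(Cl)cc(-c2nn(-c3cccc(NC(=O)c4cccc(C(F)(F)F)c4)c3)cc2-c2ccncc2)c1` is not yet measured. It differs from compound 2 in one place: 3-(trifluoromethyl)phenyl in place of (3,4-dichlorophenyl)amino on a carbonyl carbon. Among the compounds with values here, no measured step touches this part of the molecule; the single step recorded, from the methoxy change, sits on the other aryl ring and tells nothing about the amide end. Within the data shown here, the two measured values show only that both analogues with the urea give low read-outs.

With no guidance on this change, compound 3 is expected to stay at a low read-out but with wide uncertainty, the estimated step being a number 12 percentage points higher from compound 2 to compound 3 (beyond the scatter). The estimate for compound 3 is 15%, within 2% to 60%.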

Compound 3, a percentage reported as activity, at one concentration (the size of the read-out at that concentration, not a potency): 32%
Compound 3: middle estimate off by 17 percentage points, on the low side; measured number inside the range.
By their numbers in this assay, from the lowest: compounds 2 and 1 (each within the scatter of the next); then compound 3.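

In this assay the carbonyl end of the molecule responds where the methoxy change on the other aryl ring did not: replacing (3,4-dichlorophenyl)amino with 3-(trifluoromethyl)phenyl gives a number 29 percentage points higher from compound 2 to compound 3 (beyond the scatter), which means a weaker effect at the one concentration tested. This single replacement alters two features together, turning the urea into an amide by removing the nitrogen and its hydrogen while also exchanging the chlorine substituents for trifluoromethyl, so the step belongs to the whole replacement and cannot be assigned to either feature. Nothing at hand accounts for the change in read-out.

The compounds shown leave open how the step divides between the linking nitrogen and the aryl substitution; (3-(trifluoromethyl)phenyl)amino on the same carbonyl carbon, or 3,4-dichlorophenyl attached directly to it, would separate the two. Also open, going by these compounds, is whether this end of the series tolerates anything other than a substituted phenyl, such as a cyclohexyl group or a benzyl group, and whether the step would hold at concentrations other than the single one used here.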